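This account rests on a few compounds, and the source may have more. Where it says the series, first, only, none or still open, it means among the compounds named here.

Measured in a functional assay on U-937 cells (Homo sapiens) for cytotoxicity, read by MTT assay, with a stated time of 48 h; a lower number here means a stronger inhibitor, a higher number a weaker inhibitor:
- compound 1 `Fc1ccc(Nc2nc(-c3cccc(F)c3)nc3ccc(F)cc23)cc1`: > 50000 nM (a limit)
- compound 2 `Fc1cccc(Nc2nc(-c3cccc(F)c3)nc3ccc(F)cc23)c1`: 42300 nM
- compound 3 `Fc1cccc(-c2nc(Nc3cccc(Cl)c3)c3cc(F)ccc3n2)c1`: > 50000 nM (a limit)

Compound 3 gives only a limit, > 50000 nM. Across the series the main feature is the limit of > 50000 nM in this assay, at which 2 of the 3 values shown sit.

Compound 4 `Oc1ccc(Nc2nc(-c3cccc(F)c3)nc3ccc(F)cc23)cc1` carries 4-hydroxyphenyl in place of 3-chlorophenyl on a nitrogen on an aromatic ring.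

Among the measured compounds shown here, three measured steps touch this group: an at least 1.1-fold lower number from compound 1 to compound 2 (0.07 log units; that floor lies within the scatter), an at least 1.1-fold higher number from compound 2 to compound 3 (0.07 log units; that floor lies within the scatter) and a step that the two limits leave unreadable from compound 1 to compound 3. Each only exchanges one halogen-bearing phenyl for another, and none brings in a hydroxy group, so they give no direct size for this change. For the measured compounds named here, the closest anchor is compound 2, the one true number at 42300 nM.

In this assay no large change is expected, only a possible small move to a lower number, and the expected step is an at least 1.6-fold lower number from compound 3 to compound 4 (0.22 log units; that floor lies within the scatter). The estimate for compound 4 is 30000 nM, with an expected range of 10000 nM to 60000 nM.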

Compound 4, half-maximal inhibitory concentration: > 50000 nM
Compound 4 ended at the assay's limit (the forecaster's own chance of this, stated with the estimate: 45%); at least 1.6-fold (0.22 log units) between middle value and limit.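

In this assay, the hydrogen-bond donor and acceptor counted for 4-hydroxyphenyl bring no readable gain over the halogen-bearing phenyl groups on this nitrogen, and compound 4 joins the group at the limit of the series: the limit of > 50000 nM in this assay, at which 3 of the 4 values shown sit. Among the compounds shown here, the one readable step is an at least 1.1-fold higher number from compound 2 to compound 4 (0.07 log units; that floor lies within the scatter), so 4-hydroxyphenyl in place of 3-fluorophenyl shows no change that can be separated from the scatter. The steps to compound 4 from compound 1 and from compound 3 join two limits and cannot be read.

On these data alone, whether any group at this place can give a value clearly under the limit stays open, as compound 2 alone has a true number. As far as these compounds go, how an amine or a carboxylic acid on this phenyl, or a longer chain on the nitrogen, would read in this assay also stays open.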